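Replacing the acetylpiperazine of compound 2 with a sulfonamide chain

The compounds below may be only part of what the source reports. "The series", "measured", "known", "first", "only" and "open" are said of these compounds alone.

Compound 2 `CC(=O)N1CCN(c2cncc(N3C(=O)c4ccc(Cl)cc4C3(C)C)c2)CC1` was tested in an assay on cells for inhibition of cytochrome P450 11B2, mitochondrial (Homo sapiens), read by HTRF (a higher number here means a weaker inhibitor, a lower number a stronger inhibitor), and gives 9 nM. Among the three compounds measured, compound 2 stands second highest: compound 1 `CC1(C)c2cc(Cl)ccc2C(=O)N1c1cncc(N2CCN(S(C)(=O)=O)CC2)c1` gives 2 nM, and the step of a 4.5-fold higher number from compound 1 to compound 2 (0.65 log units; beyond the scatter) was modest but beyond the scatter, while compound 3 `CC1CN(c2cccnc2)C(=O)c2ccc(Cl)cc21` gives 164 nM, the highest number of the three.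

Compound 4 `CC1(C)c2cc(Cl)ccc2C(=O)N1c1cncc(CNS(C)(=O)=O)c1` differs from compound 2 in one place: (methanesulfonamido)methyl in place of 4-acetylpiperazin-1-yl on an aromatic carbon. Going by the values given here, only one measured step bears on this change, the one from compound 1 to compound 2, and it altered only the group on the ring nitrogen, not the ring itself. Among the compounds with values here, no measured step removes the six-membered non-aromatic ring and puts a group with no ring in its place, so the expectation rests on a single modest step and carries wide uncertainty.

Compound 4 is therefore expected to land near the number of compound 2, with a modest estimated step of a 2.8-fold higher number from compound 2 to compound 4 (0.44 log units; beyond the scatter) toward a higher number, giving an estimate of 25 nM with a range from 5 nM to 120 nM for compound 4.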

Compound 4, half-maximal inhibitory concentration: 33 nM
Compound 4: middle estimate off by 1.3-fold (0.12 log units), on the low side; low and high end bracket the measured number.
By their numbers in this assay, from the lowest: compound 1; then compound 2; then compound 4; then compound 3.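

In this assay, the earlier step changed only the group on the nitrogen of the six-membered non-aromatic ring, whereas this one removes that ring altogether and costs a 3.7-fold higher number from compound 2 to compound 4 (0.56 log units; beyond the scatter). A chain with no ring, carrying one hydrogen-bond donor where the 4-acetylpiperazin-1-yl group has none, therefore keeps inhibition at this position on the aromatic carbon, though the change is modest and still beyond the scatter. No measurement shown accounts for the size of this step.

Because the ring, the acetyl group and the amide hydrogen all change in this single step, their separate contributions remain unresolved. An acetamidomethyl group, a methylated sulfonamide nitrogen or a longer chain between the aromatic ring and the sulfonamide would each bear on that question, and the compounds shown include none of these.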